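The compounds below may be only part of what the source reports. "The series", "measured", "known", "first", "only" and "open" are said of these compounds alone.

Measured in a functional assay on A549 cells (Homo sapiens) for antiproliferative activity, read by MTT assay, with a stated time of 48 h; a higher number here means a weaker inhibitor, a lower number a stronger inhibitor:
- Compound 1 `COc1cc(-c2nnc3c(OC)cc(-c4ccc5[nH]ccc5c4)cn23)cc(OC)c1OC`: 167 nM
- Compound 2 `COc1cc(-c2nnc3c(OC)cc(-c4ccc5[nH]cc(C=O)c5c4)cn23)cc(OC)c1OC`: > 10000 nM (a limit of the assay, not a number)
- Compound 3 `COc1cc(-c2nnc3c(OC)cc(-c4ccc5c(ccn5C)c4)cn23)cc(OC)c1OC`: 69 nM

Compound 3, at 69 nM, gives the lower of the two numeric values. The other numeric value sits close by, with a 2.4-fold lower number from compound 1 to compound 3 (0.38 log units; beyond the scatter).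

Compound 4 `COc1cc(-c2nnc3c(OC4CC4)cc(-c4ccc5c(ccn5C)c4)cn23)cc(OC)c1OC` alters compound 3 in one place: cyclopropyl in place of methyl on an oxygen on an aromatic ring. Methoxy becomes cyclopropyloxy, and no measured step touches that oxygen, so the evidence is only indirect. Two steps elsewhere in the molecule give a sense of scale. Methyl in place of hydrogen on an aromatic nitrogen gave a 2.4-fold lower number from compound 1 to compound 3 (0.38 log units; beyond the scatter), while formyl in place of hydrogen on an aromatic carbon gave an at least 59-fold higher number from compound 1 to compound 2 (1.77 log units; beyond the scatter). A single added group can therefore matter little or a great deal in this small set. A modest move toward a higher number is expected, though with wide uncertainty, and the estimated step is a 1.9-fold higher number from compound 3 to compound 4 (0.28 log units; within the scatter). For compound 4 the estimate is 130 nM, with the value expected between 30 nM and 700 nM.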

Compound 4, half-maximal inhibitory concentration: 168 nM
For compound 4 the middle estimate is 1.3-fold (0.11 log units) below the measured one; the measured number falls inside the stated range.
By their numbers in this assay, from the lowest: compound 3; then compounds 1 and 4 (each within the scatter of the next). At a limit, above all of these: compound 2.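

Among the compounds shown here, the first change at this oxygen, read in this assay, moves the number in the weaker direction, with a 2.4-fold higher number from compound 3 to compound 4 (0.39 log units; beyond the scatter). Methoxy therefore gives the lower number of the two groups on this oxygen, although the margin is modest and compound 4 keeps a numeric value of 168 nM. Nothing in the available evidence bears on why cyclopropyloxy gives the higher number.

The compounds shown hold only methyl and cyclopropyl on this oxygen. Going by these compounds, whether an ethyl group, a longer chain or a chain ending in an amine would give a lower or a higher number there remains open, as does whether the same change would act alike with hydrogen on the aromatic nitrogen, as in compound 1.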